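The source may report more compounds than this note shows. Statements on the series, on what has been measured and on what is new or still open speak of the compounds shown alone.

Measured compounds:
compound 1, `O=C(CCCCCCc1ccccc1)c1nncs1`: > 10000 nM
compound 2, `CSc1coc(C(=O)CCCCCCc2ccccc2)n1`: > 10000 nM

Both of these numbers are limits of the assay rather than measured values. In an assay on HEK-293T cells for inhibition of diacylglycerol lipase-alpha (Homo sapiens), read by colorimetric assay (a lower number here means a stronger inhibitor, a higher number a weaker inhibitor), compound 1 reaches only the limit > 10000 nM. In this assay compound 2 likewise reaches only the limit > 10000 nM. Compound 2 therefore stands at the edge of what the assay can report, not at a definite number. Among the measured compounds shown here, the one measured step, a step that the two limits leave unreadable from compound 1 to compound 2, cannot be read in size or direction, since the limit of > 10000 nM in this assay, at which 2 of the 2 values shown sit, covers both of its ends. Compound 3, `CSc1cnc(C(=O)CCCCCCc2ccccc2)o1`, is not yet measured; it differs from compound 2 by 5-(methylsulfanyl)-1,3-oxazol-2-yl in place of 4-(methylsulfanyl)-1,3-oxazol-2-yl on a carbonyl carbon. For the measured compounds named here, no measured step gives a readable size for this kind of change. The expected step is a step that the limit leaves unreadable from compound 2 to compound 3, an estimate that assumes nothing beyond the scatter. The estimate for compound 3 is 20000 nM, with a range from 3000 nM to 100000 nM, most likely again reported only as a limit.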

Compound 3, half-maximal inhibitory concentration: > 10000 nM
Compound 3 gave a limit, no number; the forecaster's own chance of this, stated with the estimate: 85%; the middle value lies beyond the limit too.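

Compound 3 also sits at a limit rather than a number, so its steps from compound 1 and compound 2 cannot be read in size or direction: the limit of > 10000 nM in this assay, at which 3 of the 3 values shown sit. The compounds shown leave open whether these three groups on the carbonyl carbon differ at all in this assay.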